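Swapping the halogenated ring of a chalcone amide

A few compounds are considered here, and "the series" means these few. Any claim that something is new, unique, unknown or untested is made for them only; others in the source may bear on it.

Measured compounds:
- compound 1, `O=C(COc1ccc(C(=O)/C=C/c2ccc(Cl)cc2Cl)cc1)N[C@H]1CCOC1=O`: 8040 nM
- compound 2, `CCCCCCCCCCSC(=S)N[C@H]1CCOC1=O`: > 64000 nM
- compound 3, `O=C(CNc1ccc(Cl)cc1)N[C@H]1CCOC1=O`: > 64000 nM

Of the compounds shown here, three have been tested in a functional assay on PC-3 cells (Homo sapiens) for antiproliferative activity, read by MTT assay, with a stated time of 72 h; on this read-out higher numbers stand for weaker inhibition and lower numbers for stronger inhibition. Going by the values given here, compound 1 is the only one that gives a number, 8040 nM. For compound 2 the result is only a limit, > 64000 nM. For compound 3 the result is likewise only a limit, > 64000 nM. Two of the three results therefore sit at the limit of > 64000 nM in this assay, at which 2 of the 3 values shown sit, so compound 1 is the only point from which a comparison can start.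

Compound 4, `O=C(COc1ccc(C(=O)/C=C/c2ccc(Br)cc2)cc1)N[C@H]1CCOC1=O`, has not been measured. It differs from compound 1 in one place: 4-bromophenyl in place of 2,4-dichlorophenyl on a double-bonded chain carbon bound to a double-bonded chain carbon. The core of compound 1 is kept, and the change is confined to the ring on the double-bonded chain carbon. Among the compounds with values here, no pair of measured compounds shows a step of this kind, so there is no directly comparable evidence.

With only compound 1 as an anchor at 8040 nM, the expected step is small, with the estimate a 1.2-fold higher number from compound 1 to compound 4 (0.09 log units; within the scatter); the replacement of one halogenated ring by another is expected to stay within or near the scatter. Compound 4 is accordingly estimated at 10000 nM, with a range from 3000 nM to 40000 nM.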

Compound 4, half-maximal inhibitory concentration: > 64000 nM
Compound 4 ended at the assay's limit (the forecaster's own chance of this, stated with the estimate: 15%); middle value at least 6.4-fold (0.80 log units) from the limit.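

In this assay, exchanging the halogenated ring gives an at least 7.9-fold higher number from compound 1 to compound 4 (0.90 log units; beyond the scatter), so within this chalcone amide one halogenated ring cannot simply stand in for another. Compound 4 gives > 64000 nM, which is a limit of the assay and not a number. Compound 1 therefore remains the only compound with a measured number, while the others all stop at the same point: the limit of > 64000 nM in this assay, at which 3 of the 4 values shown sit.

This single change replaces both chlorines with one bromine, so the compounds shown cannot separate the effect of losing a chlorine from that of introducing bromine. As far as these compounds go, a phenyl ring with one chlorine or with two bromines could separate them, and how an unsubstituted phenyl ring would behave at this place remains open.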